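The source may hold more compounds than are shown below. What is called first, only, known or untested is meant among the compounds shown, and "the series" means these compounds.

Measured so far:
Compound 1, `COc1ccc2[nH]c(C(=O)N3CC(=O)N(Cc4ccccc4)[C@@H](CN4CCC5(CC4)CC5)C3)cc2c1`: 28200 nM
Compound 2, `COc1cccc(CN2C(=O)CN(C(=O)c3cc4cc(OC)ccc4[nH]3)C[C@@H]2CC2CCCCC2)c1`: 21400 nM
Compound 3, `COc1ccc2[nH]c(C(=O)N3CC(=O)N(Cc4cccc(OC(F)F)c4)[C@@H](CN4CCN(C5CC5)CC4)C3)cc2c1`: 99600 nM

In a physicochemical assay for solubility, read by spectrophotometry, in phosphate buffer, with a stated time of 2 h, at pH 7.4 (a lower number here means a less soluble compound, a higher number a more soluble compound), compound 1 stands second highest of the three numbers. Compound 2 sits within the scatter of compound 1, so the two cannot be told apart; compound 3 lies beyond the scatter, with the higher number. Compound 4, `COc1ccc2[nH]c(C(=O)N3CC(=O)N(Cc4ccccc4)[C@@H](CN4CCc5ccccc5C4)C3)cc2c1`, is not yet measured in this assay. It differs from compound 1 in one place: a group of 10 heavy atoms (9 carbon, 1 nitrogen; one six-membered non-aromatic ring with 1 hetero atom, one six-membered aromatic ring of carbon only) in place of a group of 8 heavy atoms (7 carbon, 1 nitrogen; one three-membered non-aromatic ring of carbon only, one six-membered non-aromatic ring with 1 hetero atom), on a saturated chain carbon bound to a saturated ring carbon. Going by the values given here, no step of this kind has been measured among the three compounds, so the expectation rests on the change alone. The step from compound 1 to compound 4 is expected to be a modest drop, a 2.4-fold lower number from compound 1 to compound 4 (0.37 log units; beyond the scatter), somewhat beyond the scatter. Compound 4 is estimated at 12000 nM, with a range from 4000 nM to 36000 nM.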

Compound 4, solubility: 9000 nM
Compound 4: middle estimate off by 1.3-fold (0.12 log units), on the high side, and the stated range covers the measured number.
By their numbers in this assay, from the lowest: compound 4; then compounds 2 and 1 (each within the scatter of the next); then compound 3.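

In this assay, putting 1,2,3,4-tetrahydroisoquinolin-2-yl in place of the group with the three-membered ring gives a 3.1-fold lower number from compound 1 to compound 4 (0.50 log units; beyond the scatter). Going by these compounds alone, this is the first comparison here that changes only one place, and it shows that the number responds to what sits on this saturated chain carbon bound to a saturated ring carbon. Nothing measured here accounts for the change. This single step cannot separate the added aromatic ring from the larger group. Going by these compounds, how a morpholine or a dimethylamino group at this place would compare also remains open.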